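Sulfonamide heteroaryl swap on the thiourea series

The source may hold more compounds than are shown below. What is called first, only, known or untested is meant among the compounds shown, and "the series" means these compounds.

Compound 1 `Cc1cc(NS(=O)(=O)c2ccc(N/C(S)=N\c3ccnc4cc(C(F)(F)F)ccc34)cc2)on1` gives 80300 nM in a functional assay on MDA-MB-231 cells (Homo sapiens) for antiproliferative activity, read by sulforhodamine B assay, with a stated time of 48 h (a lower number here means a stronger inhibitor, a higher number a weaker inhibitor), the highest number among the three measured compounds. Compound 2 `Cc1noc(NS(=O)(=O)c2ccc(N/C(S)=N\c3ccnc4cc(C(F)(F)F)ccc34)cc2)c1C` gives 27900 nM in this assay, and compound 3 `O=S(=O)(Nc1nccs1)c1ccc(N/C(S)=N\c2ccnc3cc(C(F)(F)F)ccc23)cc1` gives 24400 nM in this assay. Two steps start from compound 1: a 2.9-fold lower number from compound 1 to compound 2 (0.46 log units; beyond the scatter), and a 3.3-fold lower number from compound 1 to compound 3 (0.52 log units; beyond the scatter). The step of a 1.1-fold lower number from compound 2 to compound 3 (0.06 log units; within the scatter) shows that compounds 2 and 3 cannot be told apart.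

Compound 4 `COc1cc(NS(=O)(=O)c2ccc(N/C(S)=N\c3ccnc4cc(C(F)(F)F)ccc34)cc2)nc(OC)n1` differs from compound 1 in one place: 2,6-dimethoxypyrimidin-4-yl in place of 3-methyl-1,2-oxazol-5-yl on a sulfonamide nitrogen. Both measured steps out of compound 1 bear on this change. The step from compound 1 to compound 3 swaps the ring on the sulfonamide nitrogen, as does the change to compound 4, and the step from compound 1 to compound 2 adds to that ring; each lowered the number modestly. The change to compound 4 is larger than either, so an expected step of about the same size or somewhat bigger, toward lower numbers, is taken as a 2.7-fold lower number from compound 1 to compound 4 (0.43 log units; beyond the scatter). For compound 4 in this assay the estimate is 30000 nM, with a range from 12000 nM to 80000 nM.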

Compound 4, half-maximal inhibitory concentration: 52100 nM
Compound 4: middle estimate off by 1.7-fold (0.24 log units), on the low side; the range from low to high includes it.
By their numbers in this assay, from the lowest: compounds 3, 2, 4 and 1 (each within the scatter of the next, the first and the last beyond it).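

In this assay, the 2,6-dimethoxypyrimidin-4-yl group on the sulfonamide nitrogen cannot be separated from the 3-methyl-1,2-oxazol-5-yl group (a 1.5-fold lower number from compound 1 to compound 4 (0.19 log units; within the scatter)) or from the 3,4-dimethyl-1,2-oxazol-5-yl group (a 1.9-fold higher number from compound 2 to compound 4 (0.27 log units; within the scatter)). It can be separated from the 1,3-thiazol-2-yl group (a 2.1-fold higher number from compound 3 to compound 4 (0.33 log units; beyond the scatter)), so replacing the ring at this position does not by itself bring a change beyond the scatter from compound 1, and a six-membered aromatic ring carrying two methoxy groups gives no gain over the five-membered rings. Nothing available explains these differences.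

Still open, on these data alone, is whether the two methoxy groups or the six-membered ring itself sets the value of compound 4. Also open, as far as these compounds go, is how a plain phenyl or a pyridin-2-yl group on the sulfonamide nitrogen would read in this assay.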